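The source may report more compounds than this note shows. Statements on the series, on what has been measured and on what is new or still open speak of the compounds shown alone.

Values in an ADME assay on HEK293 cells (Homo sapiens) for cytotoxicity, read by resazurin assay, with a stated time of 24 h; a lower number here means that less compound is tolerated, a higher number that more compound is tolerated:
- compound 1 `O=C(O)c1c(O)cccc1C=Cc1ccc2ccccc2c1`: 97000 nM
- compound 2 `O=C(O)c1c(O)cccc1CCc1ccc2ccccc2c1`: > 100000 nM, a limit of the assay
- compound 3 `O=C(O)c1c(O)cc(Cl)cc1CCc1ccc2ccccc2c1`: 35000 nM

Compound 3 has the lowest number of the three, 35000 nM, while compound 1 reads 97000 nM. Compound 4 `Cc1cc(O)c(C(=O)O)c(CCc2ccc3ccccc3c2)c1` carries methyl in place of chloro on an aromatic carbon. Among the compounds with values here, one measured step bears on this change: putting chloro in place of hydrogen on that carbon gave an at least 2.8-fold lower number from compound 2 to compound 3 (0.45 log units; beyond the scatter). Within the data shown here, no methyl compound has been measured, so this step is only a rough guide. Methyl may undo part of that drop, so a small move to a higher number is expected in this assay, possibly within the scatter: a 1.6-fold higher number from compound 3 to compound 4 (0.20 log units; within the scatter). For compound 4 the estimated value is 55000 nM, with an expected range of 25000 nM to 100000 nM.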

Compound 4, half-maximal cytotoxic concentration: 40000 nM
For compound 4 the middle estimate is 1.4-fold (0.14 log units) above the measured one; measured number inside the range.
By their numbers in this assay, from the lowest: compounds 3 and 4 (each within the scatter of the next); then compound 1. At a limit, above all of these: compound 2.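

In this assay, chloro and methyl cannot be told apart at this position, which is para to the carboxy group: a 1.1-fold higher number from compound 3 to compound 4 (0.06 log units; within the scatter). Methyl in place of hydrogen also gives a step beyond the scatter, an at least 2.5-fold lower number from compound 2 to compound 4 (0.39 log units; beyond the scatter), so in this pair of compounds the drop is not tied to chloro alone. The full size of that step stays unknown because compound 2 stands at a limit of the assay: the limit of > 100000 nM in this assay, at which 1 of the 4 values shown sits.

Going by these compounds, whether an amine or a methoxy group on this carbon would give the same drop remains open. So does whether chloro or methyl would act alike on the core of compound 1.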